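Swapping a methyl for a trifluoromethyl on the pyrazole

The compounds below may be only part of what the source reports. "The series", "measured", "known", "first", "only" and "open" are said of these compounds alone.

Measured in an ADME assay on microsomes from liver (Homo sapiens) for pharmacokinetics; on this read-out higher numbers stand for fast clearance and lower numbers for slow clearance:
- compound 1 `Cc1c(Nc2nc(N)c3c(C#N)c(N4CCC[C@H]4C)n(C)c3n2)cnn1C`: 41.7 mL/min/kg
- compound 2 `Cc1nn(C2COC2)cc1Nc1nc(N)c2c(C#N)c(N3CCC[C@H]3C)n(C)c2n1`: 46.7 mL/min/kg
- compound 3 `Cc1nn(C)cc1Nc1nc(N)c2c(C#N)c(N3CCC[C@H]3C)n(C)c2n1`: 70 mL/min/kg

These three compounds share a core and differ only in the pyrazole group attached to it. At 70 mL/min/kg, compound 3 lies within the usual scatter of both other compounds, so the set shows no clear separation.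

The next compound is compound 4 `C[C@@H]1CCCN1c1c(C#N)c2c(N)nc(Nc3cn(C)nc3C(F)(F)F)nc2n1C`, which differs from compound 3 as follows: trifluoromethyl in place of methyl on an aromatic carbon. In words, this is trifluoromethyl in place of methyl on an aromatic carbon.

Going by the values given here, no measured step makes this exact swap, so the evidence is indirect. Two other changes to the pyrazole group gave small steps: a 1.7-fold higher number from compound 1 to compound 3 (0.22 log units; within the scatter) and a 1.5-fold higher number from compound 2 to compound 3 (0.18 log units; within the scatter). The remaining pair gave a 1.1-fold higher number from compound 1 to compound 2 (0.05 log units; within the scatter). All three stayed within the scatter, so no step beyond the scatter is expected in this assay, and the direction remains uncertain.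

The expected change is a 1.4-fold lower number from compound 3 to compound 4 (0.15 log units; within the scatter).

For compound 4, the estimate is 50 mL/min/kg, with an expected range of 25 mL/min/kg to 90 mL/min/kg.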

Compound 4, clearance: 33.3 mL/min/kg
Beside the measured number, compound 4's estimate is 1.5-fold (0.18 log units) above it, within the range that was stated.
By their numbers in this assay, from the lowest: compounds 4, 1, 2 and 3 (each within the scatter of the next, the first and the last beyond it).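

Read in this assay the change at this aromatic carbon, trifluoromethyl in place of methyl, gives the first step in the set that lies beyond the usual scatter, though only modestly (a 2.1-fold lower number from compound 3 to compound 4 (0.32 log units; beyond the scatter)). That separation holds only against compound 3, as the other two comparisons stay within the scatter (a 1.4-fold lower number from compound 2 to compound 4 (0.15 log units; within the scatter); a 1.3-fold lower number from compound 1 to compound 4 (0.10 log units; within the scatter)). Nothing measured here gives a reason for the step.

The compounds shown leave open whether a single fluorine, a chlorine or a cyclopropyl on this same carbon would give a similar step, or whether it is specific to trifluoromethyl. As far as these compounds go, it is also open whether the step would persist with a group other than methyl on the ring nitrogen, such as the oxetan-3-yl of compound 2.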